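Swapping Nitro for Methoxy: What to Expect for Compound 4

The compounds below may be only part of what the source reports. "The series", "measured", "known", "first", "only" and "open" are said of these compounds alone.

Of the compounds shown here, three have so far been tested in an ADME assay on MT4 cells (Homo sapiens) for cytotoxicity, read by MTT assay, with a stated time of 5 days; a lower number here means that less compound is tolerated, a higher number that more compound is tolerated. Compound 1 `Cc1cccc2sc(NN)nc12` gives 9.8 ug/mL, compound 2 `O=[N+]([O-])c1ccc(-c2nnc(-c3cccnc3)n2Nc2nc3ccc(Br)cc3s2)cc1` gives 13.2 ug/mL, and compound 3 `O=[N+]([O-])c1ccc(-c2nnc(-c3cccnc3)n2Nc2nc3ccc([N+](=O)[O-])cc3s2)cc1` gives 50.8 ug/mL, the highest of the three numbers. Within the data shown here, the only measured single-point step, a 3.8-fold higher number from compound 2 to compound 3 (0.59 log units; beyond the scatter), is also the only one that bears on the next change. Compound 4 `COc1ccc2nc(Nn3c(-c4ccc([N+](=O)[O-])cc4)nnc3-c3cccnc3)sc2c1` differs from compound 3 by methoxy in place of nitro on an aromatic carbon. Among the measured compounds shown here, since the nitro group that arrived in that step now leaves, and compound 2 without it gave 13.2 ug/mL, a move back toward the lower numbers seems likely, although methoxy is not bromo and no methoxy compound has been measured here. The step expected in this assay is a 2.5-fold lower number from compound 3 to compound 4 (0.40 log units; beyond the scatter). The estimate for compound 4 is 20 ug/mL, ranging from 8 ug/mL to 50 ug/mL.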

Compound 4, half-maximal cytotoxic concentration: 12.9 ug/mL
Estimate against measurement, compound 4: 1.6-fold (0.19 log units) above; measured number inside the range.
By their numbers in this assay, from the lowest: compounds 1, 4 and 2 (each within the scatter of the next); then compound 3.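

In this assay, methoxy in place of nitro on this aromatic carbon gives a 3.9-fold lower number from compound 3 to compound 4 (0.60 log units; beyond the scatter) and so undoes the earlier rise seen with nitro. Methoxy in place of bromo gives a 1.0-fold lower number from compound 2 to compound 4 (0.01 log units; within the scatter) and so the two groups cannot be told apart here, leaving compound 3, the nitro compound, alone at the higher number. Nothing measured here explains this difference. From the compounds shown here alone, whether that higher number is unique to nitro stays open, since an amine or a carboxylic acid on this carbon could match it. Whether a nitrile would behave like nitro or like methoxy is also unknown.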